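This account rests on a few compounds, and the source may have more. Where it says the series, first, only, none or still open, it means among the compounds named here.

Working notes on the series. Compound 1 `CCCNC(=O)C1CC12CCN(C(=O)c1cc3sc(-c4ccccc4)nc3n1Cc1ccc(OC)cc1)CC2` and compound 3 `CCCNC(=O)C1CC12CCN(C(=O)c1cc3sc(Br)nc3n1Cc1ccc(OC)cc1)CC2` share one core; compound 2 `CCCNC(=O)[C@@H]1C[C@H]2CCC[C@@H](C1)[C@@H]2NC(=O)c1cc2sc(-c3ccccc3)nc2n1Cc1ccc(OC)cc1` and compound 4 `CCCNC(=O)[C@@H]1C[C@H]2CCC[C@@H](C1)[C@@H]2NC(=O)c1cc2sc(Br)nc2n1Cc1ccc(OC)cc1` share another. How the core of compound 2 differs from the core of compound 1 is not broken down here.

In an ADME assay on HEK-293T cells (Homo sapiens) for cytotoxicity, read by luminescence and CellTiter-Glo, with a stated time of 24 h (on this read-out lower numbers stand for higher toxicity in this test and higher numbers for lower toxicity in this test), compound 1 returns only a limit, > 100000 nM. Compound 3 gives a number in this assay, namely 81300 nM. The structural difference between them is bromo in place of phenyl on an aromatic carbon, and the measured step is an at least 1.2-fold lower number from compound 1 to compound 3 (0.08 log units; that floor lies within the scatter). In this assay compound 2 likewise sits at a limit, > 100000 nM. Note (the limit of > 100000 nM in this assay, at which 2 of the 3 values shown sit), so the single measured step rests on one number set against one limit, and its true size is open at the upper end.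

Compound 4 has not yet been run in this assay. It differs from compound 2 by bromo in place of phenyl on an aromatic carbon, the same change as from compound 1 to compound 3 on the same place. Among the compounds with values here, the expectation for compound 4 is therefore a step of about the same size as the one measured, because the only instance on record is an at least 1.2-fold lower number from compound 1 to compound 3 (0.08 log units; that floor lies within the scatter) and it is small. For compound 4 the expected step is an at least 1.2-fold lower number from compound 2 to compound 4 (0.09 log units; that floor lies within the scatter). Compound 4 is estimated at 80000 nM, with a range from 40000 nM to 160000 nM, and a fair chance that this assay again reports only a limit.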

Compound 4, half-maximal cytotoxic concentration: > 100000 nM
Compound 4: only a limit was reported (the forecaster's own chance of this, stated with the estimate: 40%); middle value at least 1.2-fold (0.09 log units) away from the limit.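

Compound 2 and compound 4 both sit at a limit in this assay, and no step between them can be read for bromo in place of phenyl on an aromatic carbon: the limit of > 100000 nM in this assay, at which 3 of the 4 values shown sit.

The compounds shown leave open how large that change is on either core, and what numbers compound 1, compound 2 and compound 4 would return in place of a limit.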